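This account rests on a few compounds, and the source may have more. Where it says the series, first, only, none or still open, it means among the compounds named here.

Measured so far in the series:

compound 1 `O=C1/C(=C/c2ccccc2F)CN(C(=S)SCc2cn(Cc3ccccc3Cl)nn2)C/C1=C\c1ccccc1F` — 100000 nM
compound 2 `O=C1/C(=C/c2ccccc2F)CN(C(=S)SCc2cn(Cc3ccccc3F)nn2)C/C1=C\c1ccccc1F` — 57600 nM
compound 3 `Cc1ccc(/C=C2\CN(Cc3cn(Cc4ccccc4F)nn3)C/C(=C\c3ccc(C)cc3)C2=O)cc1` — 10000 nM

In a functional assay on MDA-MB-231 cells (Homo sapiens) for cytotoxicity, read by MTT assay, with a stated time of 24 h (a lower number here means a stronger inhibitor, a higher number a weaker inhibitor), compound 3 gives 10000 nM, the lowest number of the three, and its steps to compound 2 and to compound 1 are both beyond the scatter. Compound 3 and compound 2 differ in more than one place; the difference between the two cores is not broken down here.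

Within the core of compound 2, the change chloro in place of fluoro on an aromatic carbon gives a 1.7-fold higher number from compound 2 to compound 1 (0.24 log units; within the scatter). The same change is now applied to the core of compound 3: compound 4 `Cc1ccc(/C=C2\CN(Cc3cn(Cc4ccccc4Cl)nn3)C/C(=C\c3ccc(C)cc3)C2=O)cc1` carries chloro in place of fluoro on an aromatic carbon. The two place descriptions match word for word, so the change counts as the same one, made on a different core.

The step from compound 3 to compound 4 is expected to be a 1.4-fold higher number from compound 3 to compound 4 (0.15 log units; within the scatter), small, because a 1.7-fold higher number from compound 2 to compound 1 (0.24 log units; within the scatter) lay within the scatter. That rests on a single earlier pair, and the core is not the same, so the expectation is loose. In this assay compound 4 is estimated at 14000 nM, with a range of 6000 nM to 35000 nM.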

Compound 4, half-maximal inhibitory concentration: 29000 nM
For compound 4 the middle estimate is 2.1-fold (0.32 log units) below the measured one, and the stated range covers the measured number.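

In this assay the change from 2-fluorobenzyl to 2-chlorobenzyl on the core of compound 3 gives a 2.9-fold higher number from compound 3 to compound 4 (0.46 log units; beyond the scatter) and so runs in the same direction as on the core of compound 2. Set side by side, the two steps do not differ beyond the scatter: the same change on two cores in this assay, a 1.7-fold higher number (0.24 log units; within the scatter) from compound 2 to compound 1 and a 2.9-fold higher number (0.46 log units; beyond the scatter) from compound 3 to compound 4, 1.7-fold (0.22 log units) apart, within the scatter of two such steps

The change therefore carries across these two cores without a detectable difference in step size, even though only the newer step lies beyond the scatter on its own. Two pairs do not fix a general step size, do not show that the change would behave alike on any other core, and do not explain the higher number.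

Still open, from the compounds shown here alone, is how other groups in the same place, such as a methoxy group, a nitrile or a methyl group, would read in this assay. Also open, going by these compounds, is whether a benzyl ring with no such group would extend the same trend.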